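A few compounds are considered here, and "the series" means these few. Any claim that something is new, unique, unknown or untested is made for them only; others in the source may bear on it.

Measured compounds:
Compound 1 `CC(=O)N1CCC(n2c(-c3ccc(OCc4c(-c5c(Cl)cccc5Cl)noc4C(C)C)cc3)nc3ccc(C(=O)O)cc32)CC1`: in an assay on HEK-293T cells for antagonist activity at vitamin D3 receptor (Homo sapiens), read by a luciferase reporter, with a stated time of 24 h (on this read-out higher numbers stand for weaker inhibition and lower numbers for stronger inhibition), compound 1 gives > 10000 nM, which is a limit of the assay and not a number.
Compound 2 `CC(C)c1onc(-c2c(Cl)cccc2Cl)c1COc1ccc(-c2nc3ccc(C(=O)O)cc3n2C)c(Cl)c1`: in this assay compound 2 gives 3520 nM.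

Of the two values shown, compound 1 carries only a limit, (the limit of > 10000 nM in this assay, at which 1 of the 2 values shown sits). Compound 2 carries a measured number. Compound 3 `CC(C)Cn1c(-c2ccc(OCc3c(-c4c(Cl)cccc4Cl)noc3C(C)C)cc2)nc2ccc(C(=O)O)cc21` differs from compound 1 in one place: isobutyl in place of 1-acetylpiperidin-4-yl on an aromatic nitrogen. Among the compounds with values here, no measured step of this kind is available, so the size of the change in this assay cannot be read from the data; a modest gain in inhibition, or none beyond the scatter, is expected. Compound 3 is expected to give about 8000 nM, likely between 2000 nM and 30000 nM. That estimate means an expected step of an at least 1.2-fold lower number from compound 1 to compound 3 (0.09 log units; that floor lies within the scatter).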

Compound 3, half-maximal inhibitory concentration: 1180 nM
Compound 3: middle estimate off by 6.8-fold (0.83 log units), on the high side; the measured number lies below the stated range.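

On the aromatic nitrogen, isobutyl in place of 1-acetylpiperidin-4-yl gives an at least 8.4-fold lower number from compound 1 to compound 3 (0.92 log units; beyond the scatter) in this assay, so inhibition at this position depends on the group it carries, and a chain with no ring is tolerated. That step is only a floor, since compound 1 carries a limit of the assay and not a number: the limit of > 10000 nM in this assay, at which 1 of the 3 values shown sits.

On these data alone, what remains open is whether the gain follows from losing the ring or from losing the acetyl group. A piperidin-4-yl without the acetyl, a cyclohexyl ring or a shorter chain such as ethyl on this nitrogen would separate these possibilities.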